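Opening the Diazepane Ring of Compound 1

The source may hold more compounds than are shown below. What is called first, only, known or untested is meant among the compounds shown, and "the series" means these compounds.

Compound 1 `COc1cc(OC)c(Cl)c(-c2ccc3c(NC(=O)c4ccc(N5CCCN(C)CC5)cc4)n[nH]c3n2)c1Cl` gives 1.3 nM in a functional assay on NCI-H1581 cells (Homo sapiens) for antiproliferative activity, read by CCK-8 assay, with a stated time of 72 h (a higher number here means a weaker inhibitor, a lower number a stronger inhibitor), the lowest of the three numbers recorded. For the measured compounds named here, compound 2 `COc1cc(OC)c(Cl)c(-c2ccc3c(NC(=O)c4ccc(N5CCN(C)CC5)cc4Cl)n[nH]c3n2)c1Cl` gives 27.6 nM, and compound 3 `COc1cc(N2CCN(C)CC2)ccc1C(=O)Nc1n[nH]c2nc(-c3c(Cl)c(OC)cc(OC)c3Cl)ccc12` gives 525 nM; the only single-point step among them, a 19-fold higher number from compound 2 to compound 3 (1.28 log units; beyond the scatter), concerns a change on a different part of the molecule. Compound 4 `COc1cc(OC)c(Cl)c(-c2ccc3c(NC(=O)c4ccc(N(C)CCN(C)C)cc4)n[nH]c3n2)c1Cl` differs from compound 1 by (2-(dimethylamino)ethyl)(methyl)amino in place of 4-methyl-1,4-diazepan-1-yl on an aromatic carbon. Going by the values given here, no measured step addresses this replacement, and compounds 1 and 2 differ in two places at once, so their gap cannot be assigned to either. Among the compounds with values here, with no direct precedent, compound 4 is expected to differ only modestly from compound 1, with a 2.3-fold higher number from compound 1 to compound 4 (0.36 log units; beyond the scatter) in the direction of a higher number. Compound 4 is therefore estimated at 3 nM, within 1 nM to 10 nM.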

Compound 4, half-maximal inhibitory concentration: 11 nM
Compound 4: middle estimate off by 3.7-fold (0.56 log units), on the low side, and the stated range ends below it.
By their numbers in this assay, from the lowest: compound 1; then compound 4; then compound 2; then compound 3.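

For the compounds shown here, the step of an 8.5-fold higher number from compound 1 to compound 4 (0.93 log units; beyond the scatter) gives the first reading of this position in this assay, on an aromatic carbon para to a large group. It shows that the number is sensitive to exchanging the seven-membered 4-methyl-1,4-diazepan-1-yl ring for the open (2-(dimethylamino)ethyl)(methyl)amino chain, although the two groups have equal counts of hydrogen-bond donors and acceptors. No supporting measurement accounts for this step. Going by these compounds, whether a longer chain between the two nitrogens, or a morpholine ring, would give a lower or higher number here remains open.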